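Hydroxamate series: fluoro-hydroxyphenyl swap on two cores

The compounds below may be only part of what the source reports. "The series", "measured", "known", "first", "only" and "open" are said of these compounds alone.

Of the compounds shown here, three have been measured in an assay on isolated protein for inhibition of protein deacetylase HDAC6 (Homo sapiens), read by fluorescence, with a stated time of 15 min; on this read-out higher numbers stand for weaker inhibition and lower numbers for stronger inhibition. Compound 2 `O=C(NO)c1ccc(/C=C/c2ccnc(-c3cccc(O)c3)c2)cc1` gives 19 nM. Compound 1 `O=C(NO)c1ccc(/C=C/c2ccnc(-c3cc(F)ccc3O)c2)cc1` gives 130 nM, and the change from compound 2 to compound 1, (5-fluoro-2-hydroxyphenyl in place of 3-hydroxyphenyl on an aromatic carbon), is a step of a 6.8-fold higher number from compound 2 to compound 1 (0.84 log units; beyond the scatter). Compound 3 `O=C(NO)c1ccc(/C=C/c2cccc(-c3cccc(O)c3)c2)cc1` gives 200 nM; the difference between the core of compound 3 and the core of compound 2 is not broken down here. Compound 3 and compound 1 lie within the scatter of each other, while compound 2 sits clearly below compound 3.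

Compound 4 `O=C(NO)c1ccc(/C=C/c2cccc(-c3cc(F)ccc3O)c2)cc1` is not yet measured. It carries the same kind of change as compound 1, (5-fluoro-2-hydroxyphenyl in place of 3-hydroxyphenyl on an aromatic carbon), but the place differs: in compound 1 the change sits on a six-membered aromatic ring with 1 nitrogen, next to the ring nitrogen, whereas in compound 4 it sits on a six-membered aromatic ring of carbon only. Among the compounds with values here, only one earlier instance of this change exists, so the expected step from compound 3 to compound 4 is a 4.5-fold higher number from compound 3 to compound 4 (0.65 log units; beyond the scatter), resting on the one step seen from compound 2 to compound 1 and widened for the different core. Compound 4 is therefore expected to give about 900 nM in this assay, roughly between 250 nM and 3500 nM.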

Compound 4, half-maximal inhibitory concentration: 240 nM
Estimate against measurement, compound 4: 3.8-fold (0.57 log units) above, and the stated range ends above it.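

In this assay, the swap to 5-fluoro-2-hydroxyphenyl from 3-hydroxyphenyl gives a 1.2-fold higher number from compound 3 to compound 4 (0.08 log units; within the scatter), which is no readable change on this core. The same swap therefore does not carry a fixed step from one core to the other in this series, and a step read on one core is a poor guide to the step on the other: the same change on two cores in this assay, a 6.8-fold higher number (0.84 log units; beyond the scatter) from compound 2 to compound 1 and a 1.2-fold higher number (0.08 log units; within the scatter) from compound 3 to compound 4, 5.7-fold (0.76 log units) apart, beyond the scatter of two such steps

These two pairs do not show which feature of the cores sets the difference, nor how the swap would behave on any third core. Going by these compounds, the two aryl groups differ in both the fluorine and the placing of the hydroxyl, and the share of each in the step on either core remains open. Also open, on these data alone, is whether an amine or a methoxy group in place of the hydroxyl, or a chlorine in place of the fluorine, would show the same dependence on the core.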